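From Compound 2 to Compound 4 in Cell Tolerance

The source may report more compounds than this note shows. Statements on the series, on what has been measured and on what is new or still open speak of the compounds shown alone.

Three compounds of this series carry values in an ADME assay on Huh-7 cells (Homo sapiens) for cytotoxicity; a lower number here means that less compound is tolerated, a higher number that more compound is tolerated. Compound 1, `CN1CCN(CCNCc2cn(-c3ccc(F)cc3F)nc2-c2ccc(S(=O)(=O)N(C)C)cc2)CC1`, reaches a limit of the assay rather than a number, giving > 20000 nM. Compound 3, `CN1CCN(CCNCc2cn(-c3ccc(F)cc3F)nc2-c2ccc(C(F)(F)F)cc2)CC1`, gives 20000 nM. Among the measured compounds shown here, the one measured step, a number no higher from compound 1 to compound 3 (the limit leaves the size open), leaves its size open. Compound 2, `Cc1ccc(-n2cc(CNCCN3CCN(C)CC3)c(-c3ccccc3C)n2)c(C)c1`, likewise stands at a limit of the assay, with > 20000 nM. Compound 2 thus sits where two of the three values gather, as the limit of > 20000 nM in this assay, at which 2 of the 3 values shown sit, shows.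

Compound 4, `Cc1ccccc1-c1nn(-c2ccc(N)cc2)cc1CNCCN1CCN(C)CC1`, differs from compound 2 in one place: 4-aminophenyl in place of 2,4-dimethylphenyl on an aromatic nitrogen. For the measured compounds named here, no measured step touches this position; the step from compound 1 to compound 3 concerns trifluoromethyl in place of dimethylsulfamoyl on an aromatic carbon and, bounded by a limit, offers no size. Every value shown rests at the limit or on it. No change beyond the scatter is therefore expected from compound 2 to compound 4, and compound 4 is expected most likely to meet that limit again. The estimated step is a number no higher from compound 2 to compound 4 (the limit leaves the size open). Compound 4 is estimated at 20000 nM, with a range from 10000 nM to 40000 nM.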

Compound 4, half-maximal cytotoxic concentration: > 20000 nM
Compound 4 gave a limit, no number (the forecaster's own chance of this, stated with the estimate: 75%); the middle value lies on the limit itself.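

In this assay compound 4 reaches a limit rather than a number, > 20000 nM. Among the compounds shown here, compound 2 also stands at a limit, > 20000 nM, so no step between compound 2 and compound 4 can be read. The compounds shown leave open how much compound 2 and compound 4 tolerate in this assay, and whether 4-aminophenyl and 2,4-dimethylphenyl differ there at all.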